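The source may report more compounds than this note shows. Statements on the series, on what has been measured and on what is new or still open speak of the compounds shown alone.

Measured so far:
- compound 1 `COC1=C(OC)[C@H](O)[C@H](C/C=C(\C)CC/C=C(\C)C[C@H](O)/C=C(\C)CO)[C@@H](C)C1=O`, 12000 nM
- compound 2 `COC1=C(OC)[C@H](OC(C)=O)[C@H](C/C=C(\C)CC/C=C(\C)C[C@H](O)C=C(C)C)[C@@H](C)C1=O`, 20700 nM

Both were run in a functional assay on A549 cells (Homo sapiens) for inhibition, read by sulforhodamine B assay, with a stated time of 48 h; a higher number here means a weaker inhibitor of growth, a lower number a stronger inhibitor of growth. Compound 2 carries the highest of the two numbers, but its nearest neighbour, compound 1, falls within the scatter, so the pair is not separated. Compound 3 `COC1=C(OC)[C@H](OC(C)=O)[C@H](C/C=C(\C)CC/C=C(\C)C[C@H](O)/C=C(\C)CO)[C@@H](C)C1=O` is not yet measured. It differs from compound 2 by hydroxy in place of hydrogen on a saturated chain carbon bound to a double-bonded chain carbon. Going by the values given here, no measured pair isolates this change. Compound 2 to compound 3 is expected to show a 1.4-fold lower number from compound 2 to compound 3 (0.14 log units; within the scatter), nothing beyond the scatter. For compound 3 the estimate in this assay is 15000 nM, with a range from 6000 nM to 40000 nM.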

Compound 3, concentration for 50% growth inhibition: 29000 nM
Compound 3: middle estimate off by 1.9-fold (0.29 log units), on the low side; the measured number falls inside the stated range.
By their numbers in this assay, from the lowest: compounds 1, 2 and 3 (each within the scatter of the next, the first and the last beyond it).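

In this assay, the change from 2-methylprop-1-en-1-yl to 2-(hydroxymethyl)prop-1-en-1-yl gives a 1.4-fold higher number from compound 2 to compound 3 (0.15 log units; within the scatter) and leaves this pair unseparated, so hydroxy in place of hydrogen on this saturated chain carbon has no effect that can be read here. Acetyl in place of hydrogen on the oxygen on a saturated carbon gives a 2.4-fold higher number from compound 1 to compound 3 (0.38 log units; beyond the scatter) as the first single-place step beyond the scatter, though only a modest one. Nothing available explains either step.

Going by these compounds, whether a benzoyl or methyl group on that oxygen behaves like acetyl remains open. So does the effect of an amine or a carboxylic acid in place of the new hydroxy.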